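Side-chain methoxy on the acetamide of compound 2

This account rests on a few compounds, and the source may have more. Where it says the series, first, only, none or still open, it means among the compounds named here.

Measured in a functional assay on A549 cells (Homo sapiens) for antiproliferative activity, read by MTT assay, with a stated time of 48 h; a higher number here means a weaker inhibitor, a lower number a stronger inhibitor:
- compound 1 `COc1ccc(C(=O)c2cc(OC)c(OC)c(OC)c2)c(NC(=O)CO)c1`: 70 nM
- compound 2 `C=C(c1cc(OC)c(OC)c(OC)c1)c1ccc(OC)c(O)c1NC(C)=O`: 80 nM

Compound 2 gives 80 nM and stands level with compound 1 within the scatter, so these two values set no order. The next compound to be tested is compound 3 `C=C(c1cc(OC)c(OC)c(OC)c1)c1ccc(OC)c(O)c1NC(=O)COC`. Its change from compound 2 is methoxy in place of hydrogen on a saturated chain carbon bound to a carbonyl carbon, or acetamido to ((methoxymethyl)carbonyl)amino. Among the compounds with values here, no measured step covers this change, so the expectation is tentative. A small loss in this assay is expected, possibly no larger than the scatter. The expected size of the change is a 1.4-fold higher number from compound 2 to compound 3 (0.14 log units; within the scatter) here. Compound 3 is estimated at 110 nM, with an expected range of 30 nM to 400 nM.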

Compound 3, half-maximal inhibitory concentration: 190 nM
For compound 3 the middle estimate is 1.7-fold (0.24 log units) below the measured one; low and high end bracket the measured number.
By their numbers in this assay, from the lowest: compounds 1 and 2 (each within the scatter of the next); then compound 3.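

Within the data shown here, on the acetamido group of compound 2, methoxy in place of hydrogen on a saturated chain carbon bound to a carbonyl carbon gives the first readable step at this position. In this assay the change is a 2.4-fold higher number from compound 2 to compound 3 (0.38 log units; beyond the scatter) and counts as a modest loss, so this position does not take the added methoxy without cost. This is one replacement and sets no trend, and no measurement in hand bears on the reason for the loss.

Still open, going by these compounds, is whether the loss follows the added oxygen or the added carbon, which a plain ethyl chain in place of the methoxymethyl could help to separate. Also open, on these data alone, is whether an amine or a carboxylic acid on the same chain carbon would fare as methoxy does.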